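Dropping the bromo from compound 1: what remains of its affinity

The source may report more compounds than this note shows. Statements on the series, on what has been measured and on what is new or still open speak of the compounds shown alone.

Measured compounds:
compound 1, `Oc1ccc(CC(O)CN2CCC(O)(Cc3ccc(Br)cc3)CC2)cc1`, 2440 nM
compound 2, `Oc1ccc(C(O)CCN2CCC(Cc3ccccc3)CC2)cc1`, 24.4 nM

Of the compounds shown here, two have been measured in an assay on isolated protein for binding affinity to Adrenergic receptor alpha-1 (Homo sapiens), read by radioligand binding; on this read-out lower numbers stand for stronger inhibition and higher numbers for weaker inhibition. Compound 1 `Oc1ccc(CC(O)CN2CCC(O)(Cc3ccc(Br)cc3)CC2)cc1` gives 2440 nM, the highest of the two numbers. Going by the values given here, its nearest neighbour, compound 2 `Oc1ccc(C(O)CCN2CCC(Cc3ccccc3)CC2)cc1`, gives 24.4 nM, a much lower number, well beyond the scatter; the two compounds differ in several places at once, so no single step between them is recorded. The account now turns to compound 3 `Oc1ccc(CC(O)CN2CCC(O)(Cc3ccccc3)CC2)cc1`, which differs from compound 1 in one place only: hydrogen in place of bromo on an aromatic carbon. Among the compounds with values here, no measured pair shows this change on its own. Since nothing measured isolates the bromo, the step of a 1.6-fold lower number from compound 1 to compound 3 (0.21 log units; within the scatter) is expected to be modest, if anything toward a lower number. Compound 3 is therefore estimated at 1500 nM, within a range from 400 nM to 5000 nM.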

Compound 3, inhibition constant: 4510 nM
The estimate for compound 3 lay 3.0-fold (0.48 log units) below the measured number; low and high end bracket the measured number.
By their numbers in this assay, from the lowest: compound 2; then compounds 1 and 3 (each within the scatter of the next).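

In this assay, hydrogen in place of bromo on an aromatic carbon, para to a large group, gives a 1.8-fold higher number from compound 1 to compound 3 (0.27 log units; within the scatter). Going by these compounds alone, this pair is the first to isolate the change, and it shows that the loss of this one heavy atom leaves the two compounds indistinguishable on this read-out, so the 4-bromobenzyl and benzyl forms of this core cannot be ranked against each other. No measurement at hand offers an explanation for this result.

As far as these compounds go, it remains open whether a chloro, a methoxy or an amine on the same aromatic carbon would also stay within the scatter of compound 1 or would move the number beyond it. Also open, from the compounds shown here alone, is whether a bromo added at this place on compound 2 would read as quietly there.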